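The source may report more compounds than this note shows. Statements on the series, on what has been measured and on what is new or still open speak of the compounds shown alone.

The measured compounds: compound 1 `COc1cc(Br)cc(/C=C/C(=O)c2ccc(Cl)cc2)c1O`, compound 2 `COc1cc(Br)cc(/C=C/C(=O)c2ccc(Br)cc2)c1O`, and compound 3 `COC(=O)C1=C(N)Oc2ccc(Br)cc2C1CC(=O)c1ccccc1`; in a functional assay on MCF7 cells (Homo sapiens) for antiproliferative activity, read by sulforhodamine B assay, with a stated time of 72 h, tested at 10 uM (a higher number here means a weaker effect of the compound at the concentration tested, a lower number a stronger effect), compound 1 gives 53.3%, compound 2 gives 64.6%, and compound 3 gives 107%.

Compound 3 stands highest of the three, well apart from compound 2 and compound 1. The difference between the core of compound 3 and that of compound 2 is not broken down here.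

Compound 4 `COC(=O)C1=C(N)Oc2ccc(Cl)cc2C1CC(=O)c1ccccc1` is not yet measured. It differs from compound 3 by chloro in place of bromo on an aromatic carbon. The same kind of change, placed differently, separates compound 2 from compound 1: chloro in place of bromo on an aromatic carbon, where the step was a number 11.3 percentage points lower from compound 2 to compound 1 (beyond the scatter). Around the place the two differ: in compound 3 the ring carries the halogen on a six-membered ring of carbon only within a fused system, meta and para to a fused ring, while in compound 2 it sits para to a large group on a single ring.

Going by the values given here, for compound 4 in this assay a step of about a number 7 percentage points lower from compound 3 to compound 4 (within the scatter) is expected, resting on the one measured step of a number 11.3 percentage points lower from compound 2 to compound 1 (beyond the scatter) and on compound 3 giving 107%. Compound 4 is estimated at 100%, between 85% and 112%.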

Compound 4, a percentage reported as activity, at one concentration (the size of the read-out at that concentration, not a potency): 87.2%
Estimate against measurement, compound 4: 12.8 percentage points above; measured number inside the range.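

In this assay, chloro in place of bromo on an aromatic carbon of the core of compound 3 gives a number 19.8 percentage points lower from compound 3 to compound 4 (beyond the scatter), in the same direction as the step on the other core, a number 11.3 percentage points lower from compound 2 to compound 1 (beyond the scatter). Set side by side, the two steps cannot be told apart in size: the same change on two cores in this assay, a number 11.3 percentage points lower (beyond the scatter) from compound 2 to compound 1 and a number 19.8 percentage points lower (beyond the scatter) from compound 3 to compound 4, 8.5 percentage points apart, within the scatter of two such steps. Going by these compounds alone, this shows that the change carried over between these two cores in direction and in a size within the scatter, but it rests on only two pairs of compounds and shows neither that it would hold on a further core nor what lies behind the step.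

The compounds shown leave open whether fluoro, a nitrile or trifluoromethyl on the same aromatic carbon would continue the direction seen from bromo to chloro. They also leave open which part of the core of compound 3 sets it apart from the core of compound 2, since no pair shown differs there in one place alone.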